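This account rests on a few compounds, and the source may have more. Where it says the series, first, only, none or still open, it means among the compounds named here.

Working notes on the series. Compound 1 `O=c1cc(-c2ccccc2)c2ccc(OCC(O)CN3CCNCC3)cc2o1` carries a free amine nitrogen in its ring; compound 2 `O=c1cc(-c2ccccc2)c2ccc(OCC(O)CN3CCN(c4ccccc4)CC3)cc2o1` carries a phenyl on that nitrogen. In a functional assay on ileum for antagonist activity at histamine H1 receptor (Cavia porcellus), tested at 0.5 mg/mL (on this read-out lower numbers stand for an effect already at smaller amounts and higher numbers for an effect only at larger amounts of compound), compound 1 gives 0.0063 ug/mL, and in this assay compound 2 gives 0.0063 ug/mL. Among the measured compounds shown here, the one step measured so far, no change at the digits printed from compound 1 to compound 2 (within the scatter), shows that putting a phenyl onto the ring amine left the read-out where it was. Compound 2 therefore stands level with compound 1 at the digits shown, and no other measured compound is available for comparison.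

Compound 3 `COc1ccccc1N1CCN(CC(O)COc2ccc3c(-c4ccccc4)cc(=O)oc3c2)CC1` is the next member, not yet measured in this assay. It differs from compound 2 by methoxy in place of hydrogen on an aromatic carbon. For the measured compounds named here, no measured step touches this position directly. Going by the values given here, the only step on record, no change at the digits printed from compound 1 to compound 2 (within the scatter), is flat, so the series gives no sign of sensitivity at this end of the molecule, though a single flat step is thin ground. The expectation is accordingly a step of no change at the digits printed from compound 2 to compound 3 (within the scatter) in this assay, that is, nothing beyond the scatter. For compound 3 the estimated value is 0.0063 ug/mL, with a range from 0.002 ug/mL to 0.02 ug/mL.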

Compound 3, half-maximal effective concentration: 0.0062 ug/mL
Compound 3: middle estimate off by 1.0-fold (0.01 log units), on the high side, within the range that was stated.
By their numbers in this assay, from the lowest: compounds 3, 1 and 2 (each within the scatter of the next).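

In this assay, among the compounds shown here, methoxy in place of hydrogen on an aromatic carbon, ortho to a large group, gives a 1.0-fold lower number from compound 2 to compound 3 (0.01 log units; within the scatter) and so provides the first reading for a substituent on this six-membered aromatic ring of carbon only, which carries only hydrogen in compound 2. Taken from the free ring amine of compound 1, 2-methoxyphenyl in place of hydrogen on the amine nitrogen gives a 1.0-fold lower number from compound 1 to compound 3 (0.01 log units; within the scatter) and thus extends the earlier phenyl result: compounds 1, 2 and 3 cannot be told apart on this read-out, whether that nitrogen carries hydrogen, phenyl or 2-methoxyphenyl. No supporting measurement is available that speaks to the reason for this flat result.

Open, going by these compounds, is whether a hydroxyl group, a chlorine atom or a dimethylamino group at this place would also stay within the scatter in this assay as methoxy does. Also open, on these data alone, is whether the read-out would stay level with a benzyl group, an acetyl group or a longer alkyl chain on the ring nitrogen in place of the aromatic rings seen so far.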